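The source may report more compounds than this note shows. Statements on the series, on what has been measured and on what is new or still open speak of the compounds shown alone.

Compound 1, `CC1(C)CS(=O)(=O)CC(C)(C)N1Cl`: > 2710 h
Compound 2, `CC1(C)C(=O)N(CCO)CC(=O)N1Cl`: < 24 h

In a physicochemical assay for metabolic stability, at 40 degrees C (a lower number here means that the compound disappears faster, a higher number that the compound lasts longer), compound 1 gives > 2710 h, which is a limit of the assay rather than a number (the limit of > 2710 h in this assay, at which 1 of the 2 values shown sits). In this assay compound 2 gives < 24 h, again only a limit of the assay and not a measured number (the limit of < 24 h in this assay, at which 1 of the 2 values shown sits). Within the data shown here, no step between the two measured compounds is computed, since they differ in more than one place; their two values show only that they sit at opposite limits of this assay. Compound 2 therefore stands at the short end of what this assay can report, with no number attached to it.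

The unmeasured compound 3, `CC1(C)C(=O)N(CCS(=O)(=O)O)CC(=O)N1Cl`, is reached from compound 2 by one change: sulfo in place of hydroxy on a saturated chain carbon, two bonds along the chain from an amide-type nitrogen in a ring. Among the measured compounds shown here, the shared core of compound 2 and compound 3 is untouched, and the data hold no measured step that involves a sulfo or a hydroxy group, so no direction for this change can be read from them. In this assay the step is expected to be none beyond the scatter, a step that the limit leaves unreadable from compound 2 to compound 3, and compound 3 is expected to give about 15 h, most likely between 4 h and 60 h.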

Compound 3, half-life: 2160 h
For compound 3 the middle estimate is 140-fold (2.16 log units) below the measured one; the whole stated range lies below it.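

At this place, on a saturated chain carbon, two bonds along the chain from an amide-type nitrogen in a ring, the set now holds its first comparison of compounds that differ in one place: with sulfo in place of hydroxy, this assay gives an at least 90-fold higher number from compound 2 to compound 3 (1.95 log units; beyond the scatter). The size of this step is open at one end, since compound 2 stands at a limit of the assay and not at a number: the limit of < 24 h in this assay, at which 1 of the 3 values shown sits. With the shared core untouched, this single change is all that separates compound 2, at the short end of what this assay can report, from compound 3, which gives a measured number of 2160 h and not a limit.

The compounds shown leave open whether a step of this kind is particular to sulfo or would also appear with another group at this place, such as a carboxylic acid or an amine, or with sulfo on a longer chain. They also leave open whether the same change would have a similar effect on a different core, and how large the step from hydroxy to sulfo is as an exact number.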